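From Benzyl to (Pyridin-3-yl)methyl: A Clearance Estimate

The compounds below may be only part of what the source reports. "The series", "measured", "known", "first", "only" and "open" are said of these compounds alone.

In an ADME assay (liver) for metabolic stability, with Liver microsome (Homo sapiens) as the target, using microsomes (a lower number here means slower removal, a higher number faster removal of the compound), compound 1 (`Nc1n[nH]c2ccc(-c3nnc(NCc4ccccc4)o3)cc12`) gives 26 mL.min-1.g-1 and compound 2 (`c1ccc(CNc2nnc(-c3c[nH]c4ncccc34)o2)cc1`) gives 31 mL.min-1.g-1 and these two numbers lie within the usual scatter of each other. For the measured compounds named here, compound 2 thus stands level with the only other compound measured so far. Compound 3 (`c1cncc(CNc2nnc(-c3c[nH]c4ncccc34)o2)c1`) keeps the core of compound 2 but carries pyridin-3-yl in place of phenyl on a saturated chain carbon bound to a nitrogen on an aromatic ring. Going by the values given here, no measured pair shows this change, so the expectation rests on the structural change alone. A small move toward a lower number is expected, of a size that may not clear the scatter, and the estimate amounts to a 1.6-fold lower number from compound 2 to compound 3 (0.19 log units; within the scatter) in this assay as a tentative call. In this assay the estimate for compound 3 is 20 mL.min-1.g-1 (expected range 9 mL.min-1.g-1 to 38 mL.min-1.g-1).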

Compound 3, intrinsic clearance in microsomes: < 14 mL.min-1.g-1
Compound 3: only a limit was reported; the forecaster's own chance of this, stated with the estimate: 5%; middle value at least 1.4-fold (0.15 log units) away from the limit.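

Putting pyridin-3-yl in place of phenyl on a saturated chain carbon bound to a nitrogen on an aromatic ring gives, in this assay, an at least 2.2-fold lower number from compound 2 to compound 3 (0.34 log units; beyond the scatter). For the compounds shown here, no earlier pair of compounds differed at this position, so this is the first sign that the group held there bears on the read-out, and that the change from benzyl to (pyridin-3-yl)methyl alone is enough to move it beyond the scatter. Compound 3 is reported only as a limit and not as a number, so the step gives a minimum size and no exact one: the limit of < 14 mL.min-1.g-1 in this assay, at which 1 of the 3 values shown sits.

The compounds shown leave open how far compound 3 lies past its limit, and whether the same change would act alike on the core of compound 1. They also do not tell how pyridin-4-yl, or a phenyl carrying an amine or a carboxylic acid, would read at this place.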